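The source may hold more compounds than are shown below. What is called first, only, known or untested is meant among the compounds shown, and "the series" means these compounds.

Measured so far in a functional assay on MV4-11 cells (Homo sapiens) for antiproliferative activity, with a stated time of 6 days, tested at 6.25 uM; on this read-out higher numbers stand for a stronger effect at the one concentration tested and lower numbers for a weaker effect:
compound 1 `CNC(=O)N1CCCc2ccc(NC(=O)c3ccc(-c4ccncc4)cc3)cc21` gives 88.7%
compound 2 `CNC(=O)N1CCCc2ccc(NC(=O)c3ccc(-c4ccn(C)n4)cc3)cc21` gives 97%
compound 3 `CNC(=O)N1CCCc2ccc(NC(=O)c3ccc(-c4cnn(S(C)(=O)=O)c4)cc3)cc21` gives 40.2%

Compound 3 stands lowest of the three. Its nearest neighbour is compound 1, and that gap is a number 48.5 percentage points lower from compound 1 to compound 3 (beyond the scatter); the gap to compound 2 is even wider, a number 56.8 percentage points lower from compound 2 to compound 3 (beyond the scatter). Between compound 1 and compound 2 the step is only a number 8.3 percentage points higher from compound 1 to compound 2 (within the scatter), so the shared core tolerates either pyridin-4-yl or 1-methyl-1H-pyrazol-3-yl, while 1-(methylsulfonyl)-1H-pyrazol-4-yl drags the read-out down sharply.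

Compound 4 `CNC(=O)N1CCCc2ccc(NC(=O)c3ccc(-c4cnn(C(C)=O)c4)cc3)cc21` keeps the 1H-pyrazol-4-yl of compound 3 and changes only the group on its aromatic nitrogen: acetyl in place of methylsulfonyl on an aromatic nitrogen. Going by the values given here, no measured step swaps one group for another on that aromatic nitrogen alone; the two large steps into compound 3 change the attached ring and its substituent at once. The comparison of compound 2, bearing methyl on the aromatic nitrogen, with compound 3, bearing methylsulfonyl, only hints that this group matters. The estimate for compound 4 therefore leans on compound 3 as the closest measured neighbour, with wide uncertainty, and expects a step of a number 14.8 percentage points higher from compound 3 to compound 4 (beyond the scatter) in this assay. Compound 4 is estimated at 55%, in a range from 25% to 85%.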

Compound 4, a percentage reported as inhibition, at one concentration (the size of the read-out at that concentration, not a potency): 83.8%
Beside the measured number, compound 4's estimate is 28.8 percentage points below it; low and high end bracket the measured number.
By their numbers in this assay, from the lowest: compound 3; then compounds 4, 1 and 2 (each within the scatter of the next, the first and the last beyond it).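

In this assay the group on the aromatic nitrogen now has a step of its own: with the 1H-pyrazol-4-yl kept, acetyl in place of methylsulfonyl gives a number 43.6 percentage points higher from compound 3 to compound 4 (beyond the scatter), so this single change is enough to move the read-out a long way and a ring of this type can give a high number. Comparison with the other attached rings puts the 1-acetyl-1H-pyrazol-4-yl close to the pyridin-4-yl, with a number 4.9 percentage points lower from compound 1 to compound 4 (within the scatter), while the step to the 1-methyl-1H-pyrazol-3-yl is modest, at a number 13.2 percentage points lower from compound 2 to compound 4 (beyond the scatter), though these two steps change the ring's substitution as well as its substituent. Nothing available explains why acetyl and methylsulfonyl differ so much here.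

On these data alone, how the read-out responds to other groups on this same aromatic nitrogen, such as a longer propanoyl chain, a dimethylcarbamoyl group or a plain hydrogen, remains open. As far as these compounds go, a read-out at one concentration is also not a potency, so how compound 4 would compare with compound 1 across a range of concentrations stays unknown.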